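Swapping piperidin-1-yl for pyrrolidin-1-yl at the assay limit

A few compounds are considered here, and "the series" means these few. Any claim that something is new, unique, unknown or untested is made for them only; others in the source may bear on it.

In a functional assay on DU-145 cells (Homo sapiens) for inhibition, read by MTT assay, with a stated time of 48 h (on this read-out lower numbers stand for stronger inhibition and higher numbers for weaker inhibition), compound 1 (`CCn1c(/C=C2\SC(=O)N(CC(=O)N3CCCCC3)C2=O)nc2ccccc21`) gives > 50000 nM, which is a limit of the assay and not a number. Compound 2 (`Cn1c(/C=C2\SC(=O)N(CC(=O)N3CCCCC3)C2=O)nc2ccccc21`) gives > 50000 nM, which is likewise a limit. Together they mark (the limit of > 50000 nM in this assay, at which 2 of the 2 values shown sit). Within the data shown here, the only measured step, a step that the two limits leave unreadable from compound 1 to compound 2, concerns a different group and offers no size to carry over. Compound 3 (`CCn1c(/C=C2\SC(=O)N(CC(=O)N3CCCC3)C2=O)nc2ccccc21`) keeps the core of compound 1 and differs from it as follows: pyrrolidin-1-yl in place of piperidin-1-yl on a carbonyl carbon. So pyrrolidin-1-yl stands in place of piperidin-1-yl on a carbonyl carbon. Among the measured compounds shown here, no measured step bears on this change, so no step beyond the scatter is expected in this assay. The estimated step is a number no higher from compound 1 to compound 3 (the limit leaves the size open). Compound 3 is expected to lie near 50000 nM, within an estimated range of 20000 nM to 100000 nM, and may well be reported only as a limit.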

Compound 3, half-maximal inhibitory concentration: 45100 nM
Compound 3: middle estimate off by 1.1-fold (0.04 log units), on the high side; the measured number falls inside the stated range.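

In this assay, the change on this carbonyl carbon gives the first number among the compounds shown: compound 3, with pyrrolidin-1-yl in place of piperidin-1-yl, gives 45100 nM. From the compounds shown here alone, the change reads as an at least 1.1-fold lower number from compound 1 to compound 3 (0.04 log units; that floor lies within the scatter); compound 1 stands only at a limit, so this is a floor, and the true size of the step stays open. Even so, the compounds remain at the edge of what this assay can read: the limit of > 50000 nM in this assay, at which 2 of the 3 values shown sit.

Going by these compounds, it remains open whether any group on this carbonyl carbon, such as morpholin-4-yl or 4-methylpiperazin-1-yl, would move the number well clear of that limit. Also open, on these data alone, is whether pyrrolidin-1-yl on the core of compound 2 would give a number as well.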